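This account rests on a few compounds, and the source may have more. Where it says the series, first, only, none or still open, it means among the compounds named here.

In a functional assay on HT-29 cells (Homo sapiens) for antiproliferative activity, with a stated time of 72 h (a lower number here means a stronger inhibitor, a higher number a weaker inhibitor), the measured compounds are:

compound 1 `Cn1c(N2N=C(c3ccccc3)CC2c2ccc(F)cc2)nc(-c2ccccc2)c(C#N)c1=O` gives 8150 nM
compound 2 `Cn1c(N2N=C(c3ccccc3)CC2c2ccccc2)nc(-c2ccc(Cl)cc2)c(C#N)c1=O` gives 19500 nM
compound 3 `Cn1c(N2N=C(c3ccccc3)CC2c2ccc(F)cc2)nc(-c2ccc(Cl)cc2)c(C#N)c1=O` gives 13700 nM

Compound 3 differs from compound 1 by chloro in place of hydrogen on an aromatic carbon, and the measured step is a 1.7-fold higher number from compound 1 to compound 3 (0.23 log units; within the scatter). Compound 3 also stands next to compound 2, with a step of a 1.4-fold lower number from compound 2 to compound 3 (0.15 log units; within the scatter). The difference between the cores of compound 1 and compound 2 is not broken down here. Compound 4 `Cn1c(N2N=C(c3ccc(Cl)cc3)CC2c2ccccc2)nc(-c2ccc(Cl)cc2)c(C#N)c1=O` differs from compound 2 by chloro in place of hydrogen on an aromatic carbon; the place is described in the same words as for the change from compound 1 to compound 3, so this is the same change made on a different core. In this assay the expected step is a 1.5-fold higher number from compound 2 to compound 4 (0.19 log units; within the scatter), resting on the measured 1.7-fold higher number from compound 1 to compound 3 (0.23 log units; within the scatter), which was within the scatter. Compound 4 is therefore estimated at 30000 nM, with a range from 13000 nM to 70000 nM.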

Compound 4, half-maximal inhibitory concentration: 8720 nM
Estimate against measurement, compound 4: 3.4-fold (0.54 log units) above; measured number outside the range, below it.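

In this assay, chloro in place of hydrogen on an aromatic carbon gives a 2.2-fold lower number from compound 2 to compound 4 (0.35 log units; beyond the scatter), so the change did not carry over from the earlier core, and the two steps differ: the same change on two cores in this assay, a 1.7-fold higher number (0.23 log units; within the scatter) from compound 1 to compound 3 and a 2.2-fold lower number (0.35 log units; beyond the scatter) from compound 2 to compound 4, 3.8-fold (0.58 log units) apart, beyond the scatter of two such steps. The result shows that the step measured on one core was a poor guide to the step on the other in this series. It rests on a single pair per core, however, and does not show why the steps differ, nor whether the core or the particular phenyl group that takes the chloro matters more.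

The substituents shown on the phenyl groups are only fluoro and chloro, so the effect of a methoxy group or an amine there remains open. Also open, from the compounds shown here alone, is how a longer chain in place of the methyl group would behave.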